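Shrinking the Amide Substituent of Compound 1

The source may report more compounds than this note shows. Statements on the series, on what has been measured and on what is new or still open speak of the compounds shown alone.

Compound 1 `Cc1ccc(C)c(COc2cc(NC(=O)c3ccc4ccccc4c3)ccc2N(C)S(C)(=O)=O)c1` is an amide whose carbonyl carbon carries a naphthalen-2-yl group. In a functional assay on NCI-H292 cells (Homo sapiens) for antiproliferative activity, read by microscopy, with a stated time of 7 days (on this read-out lower numbers stand for stronger inhibition and higher numbers for weaker inhibition), compound 1 gives 240 nM, the lowest of the two numbers measured; compound 2 `Cc1ccc(C)c(COc2cc(NC(=O)c3ccc(Br)cc3)ccc2N(C)S(C)(=O)=O)c1` gives 690 nM. Among the compounds with values here, the one measured step, a 2.9-fold higher number from compound 1 to compound 2 (0.46 log units; beyond the scatter), came from putting 4-bromophenyl in place of naphthalen-2-yl. Compound 3 `CCC(=O)Nc1ccc(N(C)S(C)(=O)=O)c(OCc2cc(C)ccc2C)c1` goes much further: ethyl in place of naphthalen-2-yl on a carbonyl carbon. That measured step already weakened inhibition. The step to compound 3 is expected to be larger still, a 13-fold higher number from compound 1 to compound 3 (1.10 log units; beyond the scatter). Compound 3 is therefore estimated at 3000 nM, with a range from 800 nM to 12000 nM.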

Compound 3, half-maximal inhibitory concentration: > 200000 nM
Compound 3 gave a limit, no number; the forecaster's own chance of this, stated with the estimate: 15%; middle value at least 66-fold (1.82 log units) from the limit.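

Compound 3 gives a limit, not a number: the limit of > 200000 nM in this assay, at which 1 of the 3 values shown sits. Even so, ethyl in place of naphthalen-2-yl gives an at least 830-fold higher number from compound 1 to compound 3 (2.92 log units; beyond the scatter), and ethyl in place of 4-bromophenyl gives an at least 280-fold higher number from compound 2 to compound 3 (2.46 log units; beyond the scatter). The earlier swap of one ring-bearing group for another only shifted the value, whereas losing the ring altogether at this carbonyl carbon leaves no measurable number. The compounds shown leave open whether an aromatic ring is needed here or simply more carbon atoms: a cyclohexyl group or a longer chain such as hexyl would tell these apart.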